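Closing the hydroxyalkyl group into a ring

The source may hold more compounds than are shown below. What is called first, only, known or untested is meant among the compounds shown, and "the series" means these compounds.

Three measured compounds share one core and differ only in the group on a carbon of the five-membered aromatic ring with 3 nitrogen. Compound 1 `CC(O)c1cn(CCNc2nonc2/C(=N/O)Nc2ccc(F)c(Br)c2)nn1` gives 362 nM in an assay on isolated protein for inhibition of Indoleamine 2,3-dioxygenase 2 (Homo sapiens); on this read-out higher numbers stand for weaker inhibition and lower numbers for stronger inhibition. Compound 2 `CCC(C)(O)c1cn(CCNc2nonc2/C(=N/O)Nc2ccc(F)c(Br)c2)nn1` gives 958 nM, and compound 3 `CC(C)CC(C)(O)c1cn(CCNc2nonc2/C(=N/O)Nc2ccc(F)c(Br)c2)nn1` gives 689 nM. Compound 3 stands second highest of the three numbers; its nearest neighbour is compound 2 and its furthest is compound 1, and both of those gaps lie within the scatter. The steps among the measured compounds are a 2.6-fold higher number from compound 1 to compound 2 (0.42 log units; beyond the scatter), a 1.9-fold higher number from compound 1 to compound 3 (0.28 log units; within the scatter) and a 1.4-fold lower number from compound 2 to compound 3 (0.14 log units; within the scatter).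

Compound 4 `O/N=C(\Nc1ccc(F)c(Br)c1)c1nonc1NCCn1cc(C2(O)CCCCC2)nn1` carries 1-hydroxycyclohexyl in place of 1-hydroxy-1,3-dimethylbutyl on an aromatic carbon. All three measured steps concern the same carbon and its substituents: adding ethyl gave a modest weaker number, while adding isobutyl or exchanging methyl for isopropyl stayed within the scatter. Within the data shown here, none of them closes the chain into a ring, so that particular change has no measured precedent. With the entering and leaving groups matched in what is counted above, the expected step of a 1.0-fold higher number from compound 3 to compound 4 (0.01 log units; within the scatter) is none beyond the scatter. Compound 4 is therefore estimated to give 700 nM in this assay, with a range from 300 nM to 1600 nM.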

Compound 4, half-maximal inhibitory concentration: 865 nM
The estimate for compound 4 lay 1.2-fold (0.09 log units) below the measured number; the measured number falls inside the stated range.
By their numbers in this assay, from the lowest: compounds 1, 3, 4 and 2 (each within the scatter of the next, the first and the last beyond it).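

Closing the chain into 1-hydroxycyclohexyl keeps the heavy-atom count and swaps an open group for one six-membered ring of carbon only, and in this assay this gives a 1.3-fold higher number from compound 3 to compound 4 (0.10 log units; within the scatter) on this aromatic carbon, the first sign that a ring here reads no differently from the open 1-hydroxy-1,3-dimethylbutyl group. The comparison with the smaller open group agrees, with a 1.1-fold lower number from compound 2 to compound 4 (0.04 log units; within the scatter) also inside the scatter, while a 2.4-fold higher number from compound 1 to compound 4 (0.38 log units; beyond the scatter) lies beyond it, so compound 4 joins compound 2 in standing apart from compound 1 with its 1-hydroxyethyl group, and compound 3 is the exception, as its step from compound 1 stays within the scatter. Nothing available explains why the ring and the open chains read alike at this position.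

The compounds shown all keep a hydroxyl on the carbon attached to the aromatic ring, so they leave open how an amine or a carboxylic acid would read there, or a smaller ring such as 1-hydroxycyclopentyl. They also leave open whether any group on this carbon can give a lower number than compound 1 with its 362 nM in this assay.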